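Replacing the triazolylamino group of compound 2 at the branch carbon

The compounds below may be only part of what the source reports. "The series", "measured", "known", "first", "only" and "open" are said of these compounds alone.

Compound 1 `CC(C)C(c1ccc(-c2ccc3cccc(F)c3c2)[nH]c1=O)N1CCCCS1(=O)=O`: 14 nM
Compound 2 `CC(C)C(Nc1nnc[nH]1)c1ccc(-c2ccc3cccc(F)c3c2)[nH]c1=O`: 22 nM
Compound 3 `CC(C)C(c1ncc[nH]1)c1ccc(-c2ccc3cccc(F)c3c2)[nH]c1=O`: 7.3 nM

In an assay on CHO cells for displacement of a labelled ligand from prostaglandin E2 receptor EP3 subtype (Homo sapiens), read by radioligand binding (a lower number here means a stronger inhibitor, a higher number a weaker inhibitor), compound 2 stands at the upper end of the three numbers: the step of a 1.6-fold higher number from compound 1 to compound 2 (0.20 log units; within the scatter) is within the scatter, the step of a 3.0-fold lower number from compound 2 to compound 3 (0.48 log units; beyond the scatter) lies beyond it. Compound 4 `CC(C)C(/C=C1/CCNC1=O)c1ccc(-c2ccc3cccc(F)c3c2)[nH]c1=O` differs from compound 2 at the same place: a group of 7 heavy atoms (5 carbon, 1 nitrogen, 1 oxygen; one five-membered non-aromatic ring with 1 hetero atom) in place of a group of 6 heavy atoms (2 carbon, 4 nitrogen; one five-membered aromatic ring with 3 hetero atoms), on a saturated chain carbon bound to an aromatic carbon and a saturated chain carbon. The measured steps at this carbon are a 1.6-fold higher number from compound 1 to compound 2 (0.20 log units; within the scatter), a 1.9-fold lower number from compound 1 to compound 3 (0.28 log units; within the scatter) and a 3.0-fold lower number from compound 2 to compound 3 (0.48 log units; beyond the scatter); three quite different groups here all land within a narrow span. None of them resembles the entering group, so the direction is open, and a step no larger than those seen is expected, a 1.2-fold lower number from compound 2 to compound 4 (0.09 log units; within the scatter). Compound 4 is therefore estimated at 18 nM, with a range from 6 nM to 55 nM.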

Compound 4, inhibition constant: 5.3 nM
Compound 4: the middle estimate sits 3.4-fold (0.53 log units) above what was measured; measured number outside the range, below it.
By their numbers in this assay, from the lowest: compounds 4, 3, 1 and 2 (each within the scatter of the next, the first and the last beyond it).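

In this assay the saturated chain carbon accepts a non-aromatic five-membered ring carrying a double bond outside the ring: the step of a 4.2-fold lower number from compound 2 to compound 4 (0.62 log units; beyond the scatter) and the step of a 2.6-fold lower number from compound 1 to compound 4 (0.42 log units; beyond the scatter) both lie beyond the scatter. The step of a 1.4-fold lower number from compound 3 to compound 4 (0.14 log units; within the scatter) lies within it, so an aromatic ring at this carbon is not needed to reach the level of the imidazolyl compound. No available evidence accounts for these steps.

The compounds shown leave open whether the ring carbonyl or the amide hydrogen of the entering group matters. On these data alone, how a simple amine or a carboxylic acid would read at this carbon also remains open.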